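Sulfonamide in place of amide on an aminothiazole scaffold

The source may hold more compounds than are shown below. What is called first, only, known or untested is meant among the compounds shown, and "the series" means these compounds.

Compound 1 `O=C(Nc1ncc(Cc2ccc(Cl)cc2)s1)c1cccs1`: in an ADME assay on HepG2 2.2.15 cells (Homo sapiens) for cytotoxicity (a higher number here means that more compound is tolerated, a lower number that less compound is tolerated), compound 1 gives > 50000 nM, a limit of the assay.
Compound 2 `CC(C)(C)OC(=O)Nc1ncc(C(Oc2ccc(F)c(Cl)c2)c2ccc(Cl)cc2)s1`: in this assay compound 2 gives > 50000 nM, again a limit of the assay.
Compound 3 `O=C(Nc1ncc(C(Oc2ccc3cc(Br)ccc3c2)c2ccc(Cl)cc2)s1)C1CCCO1`: in this assay compound 3 is recorded as "not toxic" (no number reported), with no number attached.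

All three measured compounds share the same amide-bearing core, and none of them shows measurable harm to the liver-derived cells. Compound 3 therefore stands alongside the other two, at the untoxic end of the range, because two of the three values sit at the limit of > 50000 nM in this assay, at which 2 of the 3 values shown sit, and the third carries only the description of being tolerated.

Compound 4 `O=S(=O)(Nc1ncc(C(Oc2ccc3cc(Br)ccc3c2)c2ccc(Cl)cc2)s1)c1ccc(Cl)nc1` is the next compound, and it has not yet been tested. It differs from compound 3 in one place: (6-chloropyridin-3-yl)sulfonyl in place of (oxolan-2-yl)carbonyl on a nitrogen on an aromatic ring. Among the measured compounds shown here, no step between measured compounds resembles this change, so there is no measured size to lean on. Given that every compound so far is tolerated up to the assay's ceiling, the expectation is that compound 4 will behave the same way and show no cytotoxicity within the tested range. The estimate for compound 4 in this assay is 50000 nM, with a plausible span from 15000 nM to 100000 nM.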

Compound 4, half-maximal cytotoxic concentration: "not toxic" (no number reported)
No number was reported for compound 4; there is nothing to compare the estimate with.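

Among the compounds shown here, compound 3 and compound 4 are both recorded in this assay only as not toxic, with no number attached, so no step between them can be read. Left open is how much of any of these compounds the cells would tolerate before harm appears, and the numbers shown stop at one limit: the limit of > 50000 nM in this assay, at which 2 of the 4 values shown sit.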